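This account rests on a few compounds, and the source may have more. Where it says the series, first, only, none or still open, it means among the compounds named here.

Measured compounds:
- Compound 1, `COc1cccc(OC)c1OCCNCCOc1ccccc1OCc1ccccc1Cl`: 0.251 nM
- Compound 2, `COc1cccc(OC)c1OCCNCCOc1ccccc1OCc1cccc(Cl)c1`: 0.0501 nM
- Compound 3, `COc1cccc(OC)c1OCCNCCOc1ccccc1OCc1ccc(C)cc1`: 0.0631 nM

In an assay on CHO cells for displacement of a labelled ligand from Alpha-1D adrenergic receptor (Homo sapiens) (a higher number here means a weaker inhibitor, a lower number a stronger inhibitor), compound 3 stands second highest of the three numbers; its nearest neighbour is compound 2, and the step of a 1.3-fold higher number from compound 2 to compound 3 (0.10 log units; within the scatter) lies within the scatter, so the two cannot be ordered. Compound 1 stands furthest away, and the step of a 4.0-fold lower number from compound 1 to compound 3 (0.60 log units; beyond the scatter) is beyond the scatter.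

Compound 4 is `COc1cccc(OC)c1OCCNCCOc1ccccc1OCc1ccccc1[N+](=O)[O-]`. Relative to compound 3 it differs by 2-nitrophenyl in place of 4-methylphenyl on a saturated chain carbon bound to an oxygen on an aromatic ring.

Among the compounds with values here, two measured steps bear on this. The step of a 5.0-fold lower number from compound 1 to compound 2 (0.70 log units; beyond the scatter) and the step of a 4.0-fold lower number from compound 1 to compound 3 (0.60 log units; beyond the scatter) both show that moving away from 2-chlorophenyl lowered the number in this assay by a modest amount. Compound 4 brings in 2-nitrophenyl, whose substituent name places it as in the 2-chlorophenyl of compound 1, though nitro is not chloro. The reverse of the step from compound 1 to compound 3 is therefore the nearest guide, with wide uncertainty. Compound 4 is thus expected to give a higher number than compound 3, a step of about a 3.2-fold higher number from compound 3 to compound 4 (0.50 log units; beyond the scatter). The estimate for compound 4 in this assay is 0.2 nM, expected to fall between 0.05 nM and 0.8 nM.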

Compound 4, inhibition constant: 0.912 nM
Estimate against measurement, compound 4: 4.6-fold (0.66 log units) below, outside the stated range (above it).
By their numbers in this assay, from the lowest: compounds 2 and 3 (each within the scatter of the next); then compound 1; then compound 4.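

In this assay, the group itself matters as well as the ring it sits on: nitro in place of chloro on an aromatic carbon gives a 3.6-fold higher number from compound 1 to compound 4 (0.56 log units; beyond the scatter), so the number of the 2-chlorophenyl compound is not the highest that this place can reach. Against the other two compounds, 2-nitrophenyl gives a 14-fold higher number from compound 3 to compound 4 (1.16 log units; beyond the scatter) and an 18-fold higher number from compound 2 to compound 4 (1.26 log units; beyond the scatter), both large and the widest gaps among the four compounds for any change on the saturated chain carbon bound to an oxygen on an aromatic ring. Nothing measured here accounts for these steps.

The compounds shown leave open whether an amine or a carboxylic acid in place of the nitro would follow chloro, nitro or neither. Going by these compounds, it also stays open whether nitro in place of chloro on 3-chlorophenyl would give a step of similar size.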